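The source may report more compounds than this note shows. Statements on the series, on what has been measured and on what is new or still open speak of the compounds shown alone.

Compound 1 `COc1cc(-c2nnc3n2NC(c2ccco2)C(C(=O)c2ccc(Cl)cc2)S3)cc(OC)c1OC` belongs to a small set sharing one core and differing only in the aromatic group on the carbonyl carbon. In a functional assay on MCF7 cells (Homo sapiens) for cytotoxicity, read by MTT assay, with a stated time of 48 h (a lower number here means a stronger inhibitor, a higher number a weaker inhibitor), compound 1 gives > 100000 nM, a limit of the assay rather than a number. Compound 3 `COc1cc(-c2nnc3n2NC(c2ccco2)C(C(=O)c2cccc4ccccc24)S3)cc(OC)c1OC` also gives only a limit, > 100000 nM. Compound 2 `COc1cc(-c2nnc3n2NC(c2ccco2)C(C(=O)c2ccccc2)S3)cc(OC)c1OC` gives 39800 nM. Removing the chloro gave an at least 2.5-fold lower number from compound 1 to compound 2 (0.40 log units; beyond the scatter), while an at least 2.5-fold higher number from compound 2 to compound 3 (0.40 log units; beyond the scatter). Two of the three values sit at the limit of > 100000 nM in this assay, at which 2 of the 3 values shown sit.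

Compound 4 `COc1cc(-c2nnc3n2NC(c2ccco2)C(C(=O)c2cccc(Br)c2)S3)cc(OC)c1OC` carries 3-bromophenyl in place of 4-chlorophenyl on a carbonyl carbon. Among the measured compounds shown here, no measured step exchanges one halogen for another, so the direction rests on compound 1 alone, and the expected step is an at least 1.2-fold lower number from compound 1 to compound 4 (0.09 log units; that floor lies within the scatter). Compound 4 is therefore estimated at 80000 nM, with a range from 25000 nM to 250000 nM.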

Compound 4, half-maximal inhibitory concentration: 91800 nM
Estimate against measurement, compound 4: 1.1-fold (0.06 log units) below; measured number inside the range.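

Compared with plain phenyl, the 3-bromophenyl group gave a 2.3-fold higher number from compound 2 to compound 4 (0.36 log units; beyond the scatter), making it the second halogen-bearing ring, after 4-chlorophenyl, on the weaker side of phenyl. Compounds 1 and 3 are limits of the assay, so only floors can be stated: an at least 1.0-fold lower number from compound 1 to compound 4 (0.03 log units; that floor lies within the scatter) and an at least 1.0-fold lower number from compound 3 to compound 4 (0.03 log units; that floor lies within the scatter). The halogen and its place on the ring change together in this exchange, and the two effects cannot be separated here.

A 3-chlorophenyl or 4-bromophenyl group could separate them. Going by these compounds, it also stays open whether a ring carrying an amine or a methoxy group could improve on compound 2 at 39800 nM.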